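A few compounds are considered here, and "the series" means these few. Any claim that something is new, unique, unknown or untested is made for them only; others in the source may bear on it.

Compound 3 `O=c1ccc(-c2ccc3cn[nH]c3c2)cn1Cc1ccccc1F` gives 47 nM in an assay for inhibition of MAP kinase-interacting serine/threonine-protein kinase 1 (Homo sapiens), read by luminescence and ADP-Glo, with a stated time of 2 h (a lower number here means a stronger inhibitor, a higher number a weaker inhibitor), the lowest of the two numbers shown. Compound 1 `O=c1ccc(-c2ccc3cn[nH]c3c2)cn1Cc1ccccc1` gives 315 nM in this assay, and the step of a 6.7-fold lower number from compound 1 to compound 3 (0.83 log units; beyond the scatter) adds one fluoro to the aromatic ring. Compound 2 `Cn1cc(-c2ccc3cn[nH]c3c2)ccc1=O` reaches only > 2000 nM in this assay, which is a limit of the assay and not a number (the limit of > 2000 nM in this assay, at which 1 of the 3 values shown sits). Compound 4 `O=c1ccc(-c2ccc3cn[nH]c3c2)cn1Cc1ccc(Cl)c(Cl)c1` carries the change (3,4-dichlorophenyl in place of 2-fluorophenyl on a saturated chain carbon bound to an aromatic nitrogen). Among the compounds with values here, two measured steps bear on it: a 6.7-fold lower number from compound 1 to compound 3 (0.83 log units; beyond the scatter), a modest gain from one fluoro, and an at least 42-fold lower number from compound 2 to compound 3 (1.62 log units; beyond the scatter), a large gain when a 2-fluorophenyl sits on the saturated chain carbon. Since an aromatic ring remains at that place, the swap of its substituents is expected to give a 1.5-fold higher number from compound 3 to compound 4 (0.17 log units; within the scatter), a step within the scatter. Compound 4 is therefore estimated at 70 nM, between 15 nM and 300 nM.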

Compound 4, half-maximal inhibitory concentration: 62 nM
The estimate for compound 4 lay 1.1-fold (0.05 log units) above the measured number; low and high end bracket the measured number.
By their numbers in this assay, from the lowest: compounds 3 and 4 (each within the scatter of the next); then compound 1. At a limit, above all of these: compound 2.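

In this assay, the change shows a 1.3-fold higher number from compound 3 to compound 4 (0.12 log units; within the scatter), so on this saturated chain carbon bound to an aromatic nitrogen, 3,4-dichlorophenyl and 2-fluorophenyl cannot be told apart. The advantage over plain phenyl also appears with two chlorines and no fluoro, giving a 5.1-fold lower number from compound 1 to compound 4 (0.71 log units; beyond the scatter). Against hydrogen the step is an at least 32-fold lower number from compound 2 to compound 4 (1.50 log units; beyond the scatter), and the value of compound 2 is a limit of the assay: the limit of > 2000 nM in this assay, at which 1 of the 4 values shown sits.

Which of the two chlorines matters remains open, since a single chlorine at either ring position is not among these compounds. Also open, on these data alone, is how an amine, a carboxylic acid or a longer chain would compare at this place.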